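Aryl ether swap on the shared core: working notes

This account rests on a few compounds, and the source may have more. Where it says the series, first, only, none or still open, it means among the compounds named here.

Compound 1 `Nc1cc(N)c2nc(-c3ccccc3)c(Oc3ccc(Cl)c(Cl)c3)nc2c1`: in a functional assay on PC-3 cells (Homo sapiens) for inhibition, read by sulforhodamine B assay, with a stated time of 48 h (on this read-out higher numbers stand for lower toxicity in this test and lower numbers for higher toxicity in this test), compound 1 gives < 100000 nM, which is a limit of the assay and not a number.
Compound 2 `CCOC(=O)[C@H](CCC(=O)O)NC(=O)c1ccc(Sc2nc3cc(N)cc(N)c3nc2-c2ccccc2)cc1`: in this assay compound 2 gives < 100000 nM, again only a limit.

For the measured compounds named here, compound 1 thus stands only at the limit of < 100000 nM in this assay, at which 2 of the 2 values shown sit, and no step between measured compounds exists to draw on. Compound 3 `Nc1cc(N)c2nc(-c3ccccc3)c(Oc3ccc(F)cc3)nc2c1` carries 4-fluorophenyl in place of 3,4-dichlorophenyl on an oxygen on an aromatic ring. Without a measured step to rest on, only a modest shift in this assay is expected, of a size expressed as a step that the limit leaves unreadable from compound 1 to compound 3, and the result may again come back as a limit. Compound 3 is estimated at 25000 nM, within 4000 nM to 90000 nM.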

Compound 3, concentration lethal to 50% of the cells: 83200 nM
The estimate for compound 3 lay 3.3-fold (0.52 log units) below the measured number; the measured number falls inside the stated range.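

The step from compound 1 to compound 3 cannot be read, as compound 1 gives only a limit and not a number: the limit of < 100000 nM in this assay, at which 2 of the 3 values shown sit. Going by these compounds, whether 4-fluorophenyl in place of 3,4-dichlorophenyl changes the lethal concentration at all stays open.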